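This account rests on a few compounds, and the source may have more. Where it says the series, first, only, none or still open, it means among the compounds named here.

Two compounds have so far been measured in a functional assay on the whole organism (gastric juice) with Rattus norvegicus as the target; a higher number here means that more compound is needed for the effect, a lower number that less compound is needed:

Compound 1 `CC(Cn1nc(-c2ccccc2)ccc1=O)C(=N)S`: 18.2 mg/kg
Compound 2 `C/N=C(\S)C(C)Cn1ncccc1=O`: 40 mg/kg

Compound 1 stands at the lowest number of the two. Compound 2 gives the higher number, and the gap between compound 1 and compound 2 is beyond the usual scatter of this measurement. Compound 3 `N=C(S)CCn1nc(-c2ccccc2)ccc1=O` has not yet been measured in this assay. It differs from compound 1 by a single change: hydrogen in place of methyl on a saturated chain carbon bound to a carbon with a double bond to nitrogen and a saturated chain carbon. The rest of compound 1, the core and the chain carrying the thioamide-like end, is kept. For the measured compounds named here, no pair of measured compounds shows the same change, so there is nothing to compare this step to directly. With the shared core unchanged and only a methyl removed from the chain, compound 3 is expected to give a number close to that of compound 1, a step of a 1.1-fold higher number from compound 1 to compound 3 (0.04 log units; within the scatter) that is expected to stay within the scatter. Compound 3 is estimated at 20 mg/kg, with a range from 9 mg/kg to 45 mg/kg.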

Compound 3, dose for half-maximal effect: 23.2 mg/kg
Estimate against measurement, compound 3: 1.2-fold (0.06 log units) below; measured number inside the range.
By their numbers in this assay, from the lowest: compounds 1, 3 and 2 (each within the scatter of the next, the first and the last beyond it).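

In this assay, hydrogen in place of methyl on a saturated chain carbon bound to a carbon with a double bond to nitrogen and a saturated chain carbon gives a 1.3-fold higher number from compound 1 to compound 3 (0.11 log units; within the scatter), so removing this methyl brings no change that can be told from the scatter. This is the first single-place step among the compounds shown, since compound 1 and compound 2 differ in more than one place, and it shows that the methyl at this position can be lost while the number stays within the scatter of that of compound 1. Nothing measured alongside these numbers offers an explanation for this result.

Going by these compounds, whether an ethyl group, a hydroxyl group or an amine at this carbon would keep the number in the same range remains open, as only methyl and hydrogen appear there. Also open, on these data alone, is whether the same change would be as small in compound 2, whose core and thioamide-like end differ from those of compound 1.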